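This account rests on a few compounds, and the source may have more. Where it says the series, first, only, none or still open, it means among the compounds named here.

Measured in a physicochemical assay for acid dissociation:
compound 1 `COc1ccc(Oc2ccc3c(NCCCNCc4cc(F)ccc4OC)ccnc3c2)cc1`, 9.28
compound 2 `COc1cccc(CNCCCNc2ccnc3cc(Oc4ccc(Cl)cc4)ccc23)c1O`, 9.28
compound 3 `COc1ccc(F)cc1CNCCCNc1ccnc2cc(CCC(C)C)ccc12`, 9.47

Compound 2 stands level with compound 1 at the digits recorded; together they are the lowest of the three numbers, and compound 3 lies within the scatter of both. Going by the values given here, the one single-point comparison available, a number 0.19 log units higher from compound 1 to compound 3 (within the scatter), concerns a different group from the one changed here and stays within the scatter.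

Compound 4 `COc1ccc(Oc2ccc3c(NCCCNCc4cccc(OC)c4O)ccnc3c2)cc1` differs from compound 2 by methoxy in place of chloro on an aromatic carbon. Among the compounds with values here, no measured step bears directly on this swap of chloro for methoxy; the series so far has not shifted this assay beyond the scatter under any change. For compound 4 a step of a number 0.02 log units higher from compound 2 to compound 4 (within the scatter) is therefore expected, that is, none beyond the scatter. Compound 4 is estimated at 9.3, between 9 and 9.6.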

Compound 4, acid dissociation constant: 9.28
Beside the measured number, compound 4's estimate is 0.02 log units above it, and the stated range covers the measured number.
By their numbers in this assay, from the lowest: compounds 1, 2, 4 and 3 (each within the scatter of the next).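

Methoxy in place of chloro, on an aromatic carbon para to a large group, reads in this assay as no change at the digits printed from compound 2 to compound 4 (within the scatter), the first direct reading at this position. The swap of 5-fluoro-2-methoxyphenyl for 2-hydroxy-3-methoxyphenyl, on a saturated chain carbon bound to an amine nitrogen, reads as no change at the digits printed from compound 1 to compound 4 (within the scatter), so this second place also shows nothing beyond the scatter. No supporting data bear on the reason for either result. On these data alone, whether an amine or a carboxylic acid on this aromatic carbon would carry the number beyond the scatter stays open.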